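The compounds below may be only part of what the source reports. "The series", "measured", "known", "first", "only" and "open" are said of these compounds alone.

Measured compounds:
compound 1 `CC(=O)OC/C1=C/C[C@](C)(CCC=C(C)C)/C=C/[C@@H](OC(=O)C=C(C)C)[C@](C)(O)/C=C/C1=O` gives 4510 nM in a functional assay on MCF7 cells (Homo sapiens) for antiproliferative activity, read by MTT assay, with a stated time of 48 h; on this read-out lower numbers stand for stronger inhibition and higher numbers for weaker inhibition;
compound 2 `CC[Si](CC)(CC)C/C1=C/C[C@](C)(CCC=C(C)C)/C=C/[C@@H](OC(=O)C=C(C)C)[C@](C)(O)/C=C/C1=O` gives 3150 nM in this assay;
compound 3 `CC(C)=CCC[C@]1(C)/C=C/[C@@H](OC(=O)C=C(C)C)[C@](C)(O)/C=C/C(=O)/C(Cn2cc(CO)nn2)=C\C1` gives 2930 nM in this assay.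

Compound 1 carries the highest of the three numbers, but both of its neighbours lie within the scatter: a 1.4-fold lower number from compound 1 to compound 2 (0.16 log units; within the scatter) and a 1.5-fold lower number from compound 1 to compound 3 (0.19 log units; within the scatter), and likewise a 1.1-fold lower number from compound 2 to compound 3 (0.03 log units; within the scatter). Compound 4 `CO/N=C/C1=C/C[C@](C)(CCC=C(C)C)/C=C/[C@@H](OC(=O)C=C(C)C)[C@](C)(O)/C=C/C1=O` differs from compound 1 by a group of 4 heavy atoms (2 carbon, 1 nitrogen, 1 oxygen; no ring) in place of a group of 5 heavy atoms (3 carbon, 2 oxygen; no ring), on a double-bonded ring carbon. The measured steps all exchanged the group on a saturated chain carbon bound to a double-bonded ring carbon, while here the replacement sits on the double-bonded ring carbon itself, so they bear on it only loosely. Since none of them moved beyond the scatter, compound 4 is expected to stay near compound 1, with a 1.1-fold lower number from compound 1 to compound 4 (0.05 log units; within the scatter), estimated at 4000 nM within 1500 nM to 11000 nM.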

Compound 4, half-maximal inhibitory concentration: 2510 nM
Estimate against measurement, compound 4: 1.6-fold (0.20 log units) above, and the stated range covers the measured number.
By their numbers in this assay, from the lowest: compounds 4, 3, 2 and 1 (each within the scatter of the next).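

In this assay the change reaches the double-bonded ring carbon itself, not only the saturated chain carbon bound to it, and acetoxymethyl gives way with a 1.8-fold lower number from compound 1 to compound 4 (0.25 log units; within the scatter) as the result. The comparisons with the other two groups, a 1.2-fold lower number from compound 3 to compound 4 (0.07 log units; within the scatter) and a 1.3-fold lower number from compound 2 to compound 4 (0.10 log units; within the scatter), also stay within the scatter, so all four compounds remain indistinguishable in this assay. Nothing shown accounts for this lack of separation.

On these data alone, whether an amine or a carboxylic acid on this carbon would move the number beyond the scatter remains open. So does the effect of a longer chain there.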